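Cytotoxicity on skin cells: three measured amides, one awaited

A few compounds are considered here, and "the series" means these few. Any claim that something is new, unique, unknown or untested is made for them only; others in the source may bear on it.

Compound 1 `CCOC(=O)CCCCCOc1cccc(CN(C(=O)c2ccccc2)C(C)C)c1`: > 26000 nM
Compound 2 `CCOC(=O)CCCCCOc1cccc(CN(C(=O)c2ccc(-c3ccoc3)cc2)C(C)C)c1`: > 26000 nM
Compound 3 `CCOC(=O)CCCCCOc1cccc(CN(C(=O)c2ccc(-c3ccc4c(c3)OCCO4)cc2)C(C)C)c1`: > 24400 nM

In an ADME assay on BJ cells (Homo sapiens) for cytotoxicity, read by CellTiter-Glo and resazurin assay, with a stated time of 72 h (on this read-out lower numbers stand for an effect already at smaller amounts and higher numbers for an effect only at larger amounts of compound), compound 1 reaches only a limit, > 26000 nM. Compound 2 likewise gives only a limit, > 26000 nM. Compound 3 also stands at a limit, > 24400 nM, and the two other values shown are limits as well (the limit of > 24400 nM in this assay, at which 1 of the 3 values shown sits, (the limit of > 26000 nM in this assay, at which 2 of the 3 values shown sit)). The steps a step that the two limits leave unreadable from compound 1 to compound 2, a step that the two limits leave unreadable from compound 1 to compound 3 and a step that the two limits leave unreadable from compound 2 to compound 3 therefore have no readable size. Compound 4 `CCOC(=O)CCCCCOc1cccc(CN(C(=O)c2ccc(-c3cccc(C(F)(F)F)c3)cc2)C(C)C)c1` differs from compound 3 by 3-(trifluoromethyl)phenyl in place of 2,3-dihydro-1,4-benzodioxin-6-yl on an aromatic carbon. For the measured compounds named here, no measured step reads a size for such a change, so no step beyond the scatter is expected in this assay, and compound 4 is expected at 30000 nM (between 12000 nM and 80000 nM), most likely again reported as a limit. The expected step is a step that the limit leaves unreadable from compound 3 to compound 4.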

Compound 4, half-maximal effective concentration: < 1.3 nM
Compound 4 gave a limit, no number; the forecaster's own chance of this, stated with the estimate: 80%; at least 23000-fold (4.36 log units) between middle value and limit.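

Compound 4 shows that the group at this place, para to a large group, can move the read-out in this assay, which the earlier limits could not show, as the steps among compound 1, compound 2 and compound 3 cannot be read. Putting 3-(trifluoromethyl)phenyl there gives an at least 18000-fold lower number from compound 3 to compound 4 (4.27 log units; beyond the scatter), an at least 20000-fold lower number from compound 2 to compound 4 (4.30 log units; beyond the scatter) and an at least 20000-fold lower number from compound 1 to compound 4 (4.30 log units; beyond the scatter). Compound 4 itself stands at a limit, not a number: the limit of < 1.3 nM in this assay, at which 1 of the 4 values shown sits.

Going by these compounds, it stays open whether the step belongs to the trifluoromethyl group or to the phenyl ring carrying it. Also open, on these data alone, is whether a nitrile on that ring, or a carboxylic acid in place of the ethyl ester, would keep the step.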